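The compounds below may be only part of what the source reports. "The series", "measured", "known", "first", "only" and "open" are said of these compounds alone.

Measured so far:
Compound 1 `CCCCC[C@H](CCC[C@@H]1CC=CC(=O)O1)OC`: 20500 nM
Compound 2 `CCCCC[C@H](C[C@@H](O)C[C@H]1CC=CC(=O)O1)OC`: 18100 nM
Compound 3 `CCCCC[C@@H](C[C@@H](O)C[C@H]1CC=CC(=O)O1)OC`: 25200 nM

All three numbers come from a functional assay on A2780 ADR cells (Homo sapiens) for cytotoxicity, read by MTT assay, with a stated time of 24 h; on this read-out lower numbers stand for stronger inhibition and higher numbers for weaker inhibition. Compound 3 has the highest of the three, but its gap to compound 1 and its gap to compound 2 both lie within the scatter, so no order among the three is claimed. Compound 4 `CCCCC[C@@H](C[C@H](O)C[C@H]1CC=CC(=O)O1)OC` is not yet measured. It differs from compound 3 thus: the two compounds have the same atoms and bonds and differ only in configuration as drawn: 1 of 3 stereo elements differ; a stereocentre at a saturated chain carbon is drawn R in compound 3 and S in compound 4. Within the data shown here, the one measured step of the same kind, a 1.4-fold higher number from compound 2 to compound 3 (0.14 log units; within the scatter), concerns the fact that compounds 2 and 3 differ only in the configuration as drawn and stayed within the scatter. No step beyond the scatter is therefore expected for compound 4 in this assay, in either direction; the expected step is a 1.1-fold lower number from compound 3 to compound 4 (0.06 log units; within the scatter). The estimate for compound 4 is 22000 nM, within a range of 10000 nM to 45000 nM.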

Compound 4, half-maximal inhibitory concentration: 48000 nM
The estimate for compound 4 lay 2.2-fold (0.34 log units) below the measured number; measured number outside the range, above it.
By their numbers in this assay, from the lowest: compounds 2, 1, 3 and 4 (each within the scatter of the next, the first and the last beyond it).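

In this assay, the inversion at a saturated chain carbon gives a 1.9-fold higher number from compound 3 to compound 4 (0.28 log units; within the scatter), so this single change of configuration stays within the scatter, as the earlier one did. Among these compounds, two inversions together give a 2.7-fold higher number from compound 2 to compound 4 (0.42 log units; beyond the scatter), the first step beyond the scatter, though only a modest one. That step arises with no atom or bond changed: the fact that compounds 2 and 4 differ only in the configuration as drawn

Whether either stereocentre alone accounts for that step stays open, since each single step is this small. Also open, as far as these compounds go, is whether a longer chain or an amine on the chain would give a larger step than configuration does.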